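The source may hold more compounds than are shown below. What is called first, only, known or untested is meant among the compounds shown, and "the series" means these compounds.

Measured so far in a functional assay on HOP-62 cells (Homo sapiens) for inhibition, read by sulforhodamine B assay; a higher number here means a weaker inhibitor of growth, a lower number a stronger inhibitor of growth:
- Compound 1 `COc1cc(-c2ccc(-c3ccc(-c4nc5cc(C)ccc5[nH]4)cc3)cc2)cc(OC)c1OC`: 2370 nM
- Compound 2 `COc1ccc(-c2ccc(-c3ccc(-c4nc5ccccc5[nH]4)cc3)cc2)cc1OC`: 4200 nM

Compound 2 gives 4200 nM and compound 1 gives 2370 nM. These two values lie within the usual scatter of repeated measurements, so neither compound can be ranked above the other.

Compound 3 `COc1cc(-c2ccc(-c3ccc(-c4nc5ccccc5[nH]4)cc3)cc2)cc(OC)c1OC` comes from compound 2 through one change: methoxy in place of hydrogen on an aromatic carbon. This is methoxy in place of hydrogen on an aromatic carbon. Going by the values given here, no measured pair shows this change on its own, so the data give no direct size for it.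

With compound 2 at 4200 nM and compound 1 at 2370 nM, a step beyond the scatter in this assay is not expected, though a slightly lower number is likely. The expected step is a 1.4-fold lower number from compound 2 to compound 3 (0.15 log units; within the scatter). For compound 3 the estimated value is 3000 nM, with an expected range of 1300 nM to 6500 nM.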

Compound 3, concentration for 50% growth inhibition: 9430 nM
Estimate against measurement, compound 3: 3.1-fold (0.50 log units) below, and the stated range ends below it.
By their numbers in this assay, from the lowest: compounds 1 and 2 (each within the scatter of the next); then compound 3.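

In this assay, methoxy in place of hydrogen on this aromatic carbon, ortho to a methoxy group, gives a 2.2-fold higher number from compound 2 to compound 3 (0.35 log units; beyond the scatter) and so weakens growth inhibition. Compound 3 also stands apart from compound 1, where hydrogen in place of methyl on an aromatic carbon gives a 4.0-fold higher number from compound 1 to compound 3 (0.60 log units; beyond the scatter) and so the methyl goes with the stronger inhibitor in this pair. No measurement here offers a reason for either step.

The compounds shown leave open whether a hydroxyl or a fluorine on this same carbon would weaken growth inhibition as methoxy does. They also leave open whether an ethyl or a chlorine in place of the methyl would keep the inhibition seen with compound 1.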